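Benzyl to fluorophenoxyethyl: the step to compound 4

The source may hold more compounds than are shown below. What is called first, only, known or untested is meant among the compounds shown, and "the series" means these compounds.

Measured so far:
compound 1, `C[C@H](NC(=O)c1nnn(Cc2cccc(C(F)(F)F)c2)c1C(F)(F)F)c1ccc(C(=O)O)cc1`, > 10000 nM
compound 2, `CCCc1nnn(Cc2ccc(C(F)(F)F)cc2)c1C(=O)N[C@@H](C)c1ccc(C(=O)O)cc1`, 68.8 nM
compound 3, `C[C@H](NC(=O)c1c(-c2ccccc2)nnn1Cc1ccccc1)c1ccc(C(=O)O)cc1`, 647 nM

In a functional assay on CHO cells for antagonist activity at prostaglandin E2 receptor EP4 subtype (Homo sapiens), read by calcium flux, with a stated time of 15 min (on this read-out higher numbers stand for weaker inhibition and lower numbers for stronger inhibition), compound 1 reaches only a limit of the assay, (the limit of > 10000 nM in this assay, at which 1 of the 3 values shown sits), and not a number. Compound 2 gives 68.8 nM in this assay. Compound 3 gives 647 nM, the higher of the two numbers, with compound 2 sitting lower by a gap beyond the scatter. Compound 4, `C[C@H](NC(=O)c1c(-c2ccccc2)nnn1CCOc1ccc(F)cc1)c1ccc(C(=O)O)cc1`, differs from compound 3 by (4-fluorophenoxy)methyl in place of phenyl on a saturated chain carbon bound to an aromatic nitrogen; cut one bond further out this reads benzyl to 2-(4-fluorophenoxy)ethyl. Within the data shown here, no pair of measured compounds shows this change, so its size is open. Compound 4 is expected to move by a 1.1-fold lower number from compound 3 to compound 4 (0.03 log units; within the scatter), a step within the scatter. The estimate for compound 4 in this assay is 600 nM, between 120 nM and 3000 nM.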

Compound 4, half-maximal inhibitory concentration: 3.1 nM
Beside the measured number, compound 4's estimate is 190-fold (2.29 log units) above it, and the stated range ends above it.
By their numbers in this assay, from the lowest: compound 4; then compound 2; then compound 3. At a limit, above all of these: compound 1.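

In this assay, exchanging benzyl for 2-(4-fluorophenoxy)ethyl gives a 210-fold lower number from compound 3 to compound 4 (2.32 log units; beyond the scatter). Among these compounds, the group at this place, on a saturated chain carbon bound to an aromatic nitrogen, can therefore change inhibition strongly with the rest of the molecule held fixed, which the earlier compounds could not show, as no two of them differed in one place only. Nothing measured here accounts for the size of this step.

From the compounds shown here alone, whether the step belongs to the ether oxygen, the fluorine or the longer chain stays open. A 2-phenoxyethyl or a 3-phenylpropyl group at this place would separate these.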